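The source may report more compounds than this note shows. Statements on the series, on what has been measured and on what is new or still open speak of the compounds shown alone.

In a functional assay on OVCAR-5 cells (Homo sapiens) for cytotoxicity, read by sulforhodamine B assay, with a stated time of 48 h (a higher number here means a weaker inhibitor of growth, a lower number a stronger inhibitor of growth), compound 1 `ClCc1ccc(Cn2cnc3c(Cl)ncnc32)cc1` gives 2950 nM. Compound 2 `Nc1nc(Cl)c2ncn(Cc3ccc(CCl)cc3)c2n1` differs from it by one change, (amino in place of hydrogen on an aromatic carbon), and gives 3310 nM, so the step of a 1.1-fold higher number from compound 1 to compound 2 (0.05 log units; within the scatter) is a small one. Compound 3 `ClCc1ccccc1Cn1cnc2c(Cl)ncnc21` is built from the same atoms as compound 1, joined differently; the difference between the two cores is not broken down here. Compound 3 gives 2450 nM. Compound 4 `Nc1nc(Cl)c2ncn(Cc3ccccc3CCl)c2n1` is compound 3 with the same change, (amino in place of hydrogen on an aromatic carbon), at a place described in the same words as before. Compound 4 has not yet been measured. The step of a 1.1-fold higher number from compound 3 to compound 4 (0.04 log units; within the scatter) is expected to be small because a 1.1-fold higher number from compound 1 to compound 2 (0.05 log units; within the scatter) stayed within the scatter. Compound 4 is therefore estimated to give 2700 nM, with a likely range from 1400 nM to 5500 nM.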

Compound 4, concentration for 50% growth inhibition: 20000 nM
Beside the measured number, compound 4's estimate is 7.4-fold (0.87 log units) below it; the whole stated range lies below it.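

In this assay the amino group in place of hydrogen brings an 8.2-fold higher number from compound 3 to compound 4 (0.91 log units; beyond the scatter) and so a weaker inhibitor of growth on this core. The change does not carry over at the same size from one core to the other: the same change on two cores in this assay, a 1.1-fold higher number (0.05 log units; within the scatter) from compound 1 to compound 2 and an 8.2-fold higher number (0.91 log units; beyond the scatter) from compound 3 to compound 4, 7.3-fold (0.86 log units) apart, beyond the scatter of two such steps. A step read on the core of compound 1 is therefore a poor guide to the core of compound 3, but two pairs do not show why the cores part ways or how the change would behave on a further core.

The compounds shown leave open whether a methylamino group or a hydroxyl group in the same place would split the two cores in the same way.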